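The source may hold more compounds than are shown below. What is called first, only, known or untested is meant among the compounds shown, and "the series" means these compounds.

The measured compounds:
compound 1, `COc1cc(-n2cnc3ccc(-c4ccccc4)cc32)cc(OC)c1OC`, gives 3060 nM in a functional assay on A549 cells (Homo sapiens) for antiproliferative activity, read by MTT assay, with a stated time of 72 h; a lower number here means a stronger inhibitor, a higher number a weaker inhibitor
compound 2, `COc1cc(-n2cnc3ccc(-c4cccc([N+](=O)[O-])c4)cc32)cc(OC)c1OC`, gives 5410 nM in this assay
compound 3, `COc1cc(-c2ccc3ncn(-c4cc(OC)c(OC)c(OC)c4)c3c2)cc(OC)c1OC`, gives only a limit in this assay: > 10000 nM

Of the two numbers shown, compound 1 gives the lowest; its nearest neighbour is compound 2, and the step of a 1.8-fold higher number from compound 1 to compound 2 (0.25 log units; within the scatter) lies within the scatter. Compound 3 is reported as a limit, (the limit of > 10000 nM in this assay, at which 1 of the 3 values shown sits), and supplies no number for comparison. Compound 4, `COc1cc(-n2cnc3ccc(-c4ccc(C)cc4)cc32)cc(OC)c1OC`, differs from compound 1 in a single place: methyl in place of hydrogen on an aromatic carbon. Among the compounds with values here, the only measured step that bears on this change is a 1.8-fold higher number from compound 1 to compound 2 (0.25 log units; within the scatter), which arose from nitro in place of hydrogen on an aromatic carbon of the same six-membered aromatic ring of carbon only and did not move the number beyond the scatter. Within the data shown here, no measured step concerns methyl in place of hydrogen, so the expectation rests on that single step. The step of a 1.0-fold lower number from compound 1 to compound 4 (0.01 log units; within the scatter) is therefore expected to stay within the scatter, in no particular direction. The estimate for compound 4 in this assay is 3000 nM, with a range from 1400 nM to 6500 nM.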

Compound 4, half-maximal inhibitory concentration: 1940 nM
Beside the measured number, compound 4's estimate is 1.5-fold (0.19 log units) above it; the measured number falls inside the stated range.
By their numbers in this assay, from the lowest: compounds 4, 1 and 2 (each within the scatter of the next, the first and the last beyond it). At a limit, above all of these: compound 3.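

In this assay, the methyl on an aromatic carbon para to a large group gives a 1.6-fold lower number from compound 1 to compound 4 (0.20 log units; within the scatter), so phenyl and 4-methylphenyl cannot be told apart at this position. The earlier compounds shown here showed no step on this ring that passed the scatter, whereas a 2.8-fold lower number from compound 2 to compound 4 (0.45 log units; beyond the scatter) is a modest step beyond it, even though compound 2 and compound 4 each lie within the scatter of compound 1. This step replaces 3-nitrophenyl with 4-methylphenyl, so it changes both the group and its place on the ring, and nothing measured here explains it or assigns it to either change.

On these data alone, it remains open whether another group at this place, such as an amine, a carboxylic acid or a longer chain, would move the number beyond the scatter from compound 1. Compound 3 gives only a limit of > 10000 nM in this assay and so leaves open how far its true number lies from the others.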